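This account rests on a few compounds, and the source may have more. Where it says the series, first, only, none or still open, it means among the compounds named here.

In a functional assay on HeLa cells (Homo sapiens) for antiproliferative activity, read by MTT assay, with a stated time of 48 h (on this read-out lower numbers stand for stronger inhibition and higher numbers for weaker inhibition), two compounds sharing one core have been measured. For the measured compounds named here, compound 1 (`COc1ccc(-c2cc3c(cn2)[nH]c(=O)n3-c2cc(OC)c(OC)c(OC)c2)cc1O`) gives 490 nM and compound 2 (`COc1ccc(-c2cc3c(cn2)[nH]c(=O)n3-c2cc(OC)c(OC)c(OC)c2)cc1N`) gives 770 nM, so compound 1 stands within the scatter of its only measured neighbour. Compound 3 (`COc1ccc(-c2cc3c(cn2)n(C2CC2)c(=O)n3-c2cc(OC)c(OC)c(OC)c2)cc1O`) keeps everything in compound 1 except for one change, cyclopropyl in place of hydrogen on an aromatic nitrogen.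

Going by the values given here, only one measured step is available, a 1.6-fold higher number from compound 1 to compound 2 (0.20 log units; within the scatter). It puts amino in place of hydroxy on an aromatic carbon, so it is a change at a different place and says little about the nitrogen. Among the compounds with values here, no measured compound carries any group on that nitrogen, and the data therefore give no direct guide to the size or direction of this step. Within the data shown here, with only that small step from compound 1 to compound 2 to go on, no shift clearly beyond the scatter is expected in this assay, though the uncertainty is wide in both directions. The expected change is a 1.6-fold lower number from compound 1 to compound 3 (0.21 log units; within the scatter). For compound 3 the estimated value is 300 nM, with an expected range from 50 nM to 1500 nM.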

Compound 3, half-maximal inhibitory concentration: > 20000 nM
Compound 3: no number, only a limit; the forecaster's own chance of this, stated with the estimate: 5%; middle value at least 66-fold (1.82 log units) from the limit.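

In this assay compound 3 gives > 20000 nM, which is a limit of the assay and not a number: the limit of > 20000 nM in this assay, at which 1 of the 3 values shown sits. Even so, the step can be read as an at least 40-fold higher number from compound 1 to compound 3 (1.61 log units; beyond the scatter), so cyclopropyl in place of hydrogen on this aromatic nitrogen of the five-membered aromatic ring removes nearly all of the measured antiproliferative effect. Compounds 1 and 2 both carry the hydrogen on this nitrogen and differ only at another place, so they gave no sign that this position could matter so much, whereas this single change shows that the activity of the core of compound 1 does not survive cyclopropyl here.

The compounds shown leave open whether any group on this nitrogen gives the same loss or whether it is particular to cyclopropyl, as a methyl group or a 2-hydroxyethyl chain in its place would be needed to separate the two. They also leave open how far activity really falls beyond the limit, and whether the amino analogue, compound 2, would respond to cyclopropyl on this nitrogen as compound 1 does.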